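This account rests on a few compounds, and the source may have more. Where it says the series, first, only, none or still open, it means among the compounds named here.

Measured so far:
- compound 1, `CCCCCC[C@@H](O)C/C=C\CCCCCCCCSCCC(=O)NCc1ccc(O)c(OC)c1`: "not determined" (no result reported)
- compound 2, `CCCCCCCC/C=C\CCCCCCCC[Se]CCC(=O)NCc1ccc(O)c(OC)c1`: 3200 nM
- compound 3, `CCCCCCCCCCCCCCCC(N)=O`: > 10000 nM

In an assay on HEK293 cells for antagonist activity at transient receptor potential cation channel subfamily V member 2 (Rattus norvegicus), read by fluorescence and calcium flux, with a stated time of 5 min (a higher number here means a weaker inhibitor, a lower number a stronger inhibitor), compound 1 has no reported number; its result stands as "not determined" (no result reported). Among the compounds with values here, compound 2 is the only member with a measured figure, giving 3200 nM in this assay. Compound 3 gives only a limit of the assay, > 10000 nM, so no number is available for it either; this is the limit of > 10000 nM in this assay, at which 1 of the 3 values shown sits. Compound 1 therefore cannot be placed against the others by a value of its own.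

The step to compound 4, `CCCCC/C=C\C/C=C\CCCCCCCCSCCC(=O)NCc1ccc(O)c(OC)c1`, changes the chain in one place: hept-1-en-1-yl in place of 1-hydroxyheptyl on a saturated chain carbon bound to a double-bonded chain carbon. With no measured pair of this kind in the set, no sign or size can be taken from data; within this assay the closest reference is the chain-linked amide of compound 2. The expectation is that the change from compound 1 to compound 4 stays close to that figure, without any step beyond the scatter being foreseen.

Compound 4 is expected to give about 3000 nM in this assay, within 800 nM to 10000 nM, guided by compound 2 at 3200 nM.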

Compound 4, half-maximal inhibitory concentration: 2800 nM
For compound 4 the middle estimate is 1.1-fold (0.03 log units) above the measured one; low and high end bracket the measured number.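

In this assay, within the data shown here, compound 1 stands as "not determined" (no result reported) and compound 4 gives 2800 nM with no step between them that can be read. The compounds shown leave open what replacing 1-hydroxyheptyl with hept-1-en-1-yl does to inhibition. Nothing at hand bears on the value of compound 4.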